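A Piperidine Ester Replaces the Tetrahydroquinoline

The compounds below may be only part of what the source reports. "The series", "measured", "known", "first", "only" and "open" are said of these compounds alone.

Of the compounds shown here, three built on one shared core have been tested in a functional assay on HT-29 cells (Homo sapiens) for inhibition, read by sulforhodamine B assay; on this read-out higher numbers stand for weaker inhibition and lower numbers for stronger inhibition. For compound 1 `COC(=O)CC/C(C)=C/Cc1c(OC)c(C)c2c(c1OCC#CCN1CCN(c3ccc(C)cc3)CC1)C(=O)OC2` this assay gives a limit, > 50000 nM, rather than a number. Compound 2 `COC(=O)CC/C(C)=C/Cc1c(OC)c(C)c2c(c1OCC#CCN1CCN(C(c3ccccc3)c3ccccc3)CC1)C(=O)OC2` likewise returns a limit, > 50000 nM. Compound 3 `COC(=O)CC/C(C)=C/Cc1c(OC)c(C)c2c(c1OCC#CCN1CCCc3ccccc31)C(=O)OC2` also stops at a limit, > 50000 nM. So the whole set sits at one place, namely (the limit of > 50000 nM in this assay, at which 3 of the 3 values shown sit), and none of the three can be ranked against the others; all that is known is that none of them inhibits the cells within the range the assay can resolve.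

Compound 4 `COC(=O)CC/C(C)=C/Cc1c(OC)c(C)c2c(c1OCC#CCN1CCC(C(=O)OC)CC1)C(=O)OC2` keeps the core of compound 3 and alters the group at the end of the alkyne-bearing chain: 4-(methoxycarbonyl)piperidin-1-yl in place of 1,2,3,4-tetrahydroquinolin-1-yl on a saturated chain carbon bound to a triple-bonded carbon. For the measured compounds named here, no measured pair in this set differs in a single place, so there is no step to lean on, and nothing in the three limits points in either direction. With every neighbour at the limit, the step from compound 3 to compound 4 is expected to be none beyond the scatter, a number no higher from compound 3 to compound 4 (the limit leaves the size open). Compound 4 is therefore expected to give about 50000 nM in this assay, within a range of 20000 nM to 120000 nM, and most probably to be reported as a limit once more.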

Compound 4, half-maximal inhibitory concentration: > 50000 nM
Compound 4 gave a limit, no number; the forecaster's own chance of this, stated with the estimate: 80%; the middle value sits exactly at the limit.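

Compound 3 and compound 4 both stop at a limit in this assay, so the swap of 1,2,3,4-tetrahydroquinolin-1-yl for 4-(methoxycarbonyl)piperidin-1-yl yields no readable step. The whole set shares one place: the limit of > 50000 nM in this assay, at which 4 of the 4 values shown sit.

The compounds shown leave open whether any change on this shared core can bring a measurable number in this assay.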